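Cyclopropyl in Place of a Dimethylaminoethyl Tail

A few compounds are considered here, and "the series" means these few. Any claim that something is new, unique, unknown or untested is made for them only; others in the source may bear on it.

Of the compounds shown here, three with a shared core have been measured in a functional assay on U-87MG ATCC cells for antiproliferative activity against U-87 MG (Homo sapiens), read by MTT assay, with a stated time of 72 h; a lower number here means a stronger inhibitor, a higher number a weaker inhibitor. Compound 1 `COc1ncc(-c2ccc3nc(NC(=O)NCCN4CCCC4)sc3c2)cc1NS(=O)(=O)c1ccc(F)cc1` gives 360 nM, and compound 3 `CCN(CC)CCNC(=O)Nc1nc2ccc(-c3cnc(OC)c(NS(=O)(=O)c4ccc(C)cc4)c3)cc2s1` gives 360 nM. Compound 2 `COc1ncc(-c2ccc3nc(NC(=O)NCCN(C)C)sc3c2)cc1NS(=O)(=O)c1ccc(F)cc1` gives 1020 nM, which is the highest of the three numbers; its nearest neighbour is compound 1, and compound 3 sits the same distance away. Within the data shown here, the only measured step that is a single change is a 2.8-fold higher number from compound 1 to compound 2 (0.45 log units; beyond the scatter), so swapping one small nitrogen-bearing group for another at the end of the chain already shifts the number beyond the scatter.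

Compound 4 `COc1ncc(-c2ccc3nc(NC(=O)NC4CC4)sc3c2)cc1NS(=O)(=O)c1ccc(F)cc1` goes further: cyclopropyl in place of 2-(dimethylamino)ethyl on an amide-type nitrogen. Among the measured compounds shown here, no measured step bears directly on this change, since every measured compound keeps a nitrogen-bearing chain on that amide-type nitrogen and compound 4 removes it. The step from compound 1 to compound 2 shows that this part of the molecule matters, but it gives no direction for a change of this kind. The expectation is therefore a modest step in either direction, with a 1.7-fold lower number from compound 2 to compound 4 (0.23 log units; within the scatter) as the estimate, leaning slightly toward a lower number. For compound 4 the estimated value in this assay is 600 nM, with a range from 200 nM to 2000 nM.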

Compound 4, half-maximal inhibitory concentration: 520 nM
Beside the measured number, compound 4's estimate is 1.2-fold (0.06 log units) above it; measured number inside the range.
By their numbers in this assay, from the lowest: compounds 1, 3, 4 and 2 (each within the scatter of the next, the first and the last beyond it).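

In this assay the group on the amide-type nitrogen does not need a nitrogen-bearing chain to keep a number in this range: cyclopropyl in place of 2-(dimethylamino)ethyl gives a 2.0-fold lower number from compound 2 to compound 4 (0.29 log units; within the scatter) and cyclopropyl in place of 2-(pyrrolidin-1-yl)ethyl gives a 1.4-fold higher number from compound 1 to compound 4 (0.16 log units; within the scatter). Among these compounds, until now this position had only been seen carrying chains that end in a nitrogen, and the one measured step among them, a 2.8-fold higher number from compound 1 to compound 2 (0.45 log units; beyond the scatter), suggested that small edits there could move the number; compound 4 now sits within the scatter of both of those compounds, even though the two lie beyond the scatter of each other. Nothing available explains why a ring of carbon only can stand in for these chains here.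

On these data alone, whether a larger carbon-only ring such as cyclohexyl, or a chain ending in a carboxylic acid, would hold the number at this amide-type nitrogen remains open. As far as these compounds go, it is also open whether cyclopropyl would read the same way on the core of compound 3, which carries a diethylamino-ended chain.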